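The source may report more compounds than this note shows. Statements on the series, on what has been measured and on what is new or still open speak of the compounds shown alone.

Measured so far in a functional assay on CHO cells for agonist activity at adenosine receptor A1 (Homo sapiens), read by fluorescence and ERK phosphorylation, with stated times of 30 min and 1.5 h, tested at 10 uM; a higher number here means a stronger effect of the compound at the concentration tested, a lower number a weaker effect:

compound 1, `Nc1scc(-c2cccc([N+](=O)[O-])c2)c1C(=O)c1ccccc1`, gives 50%
compound 2, `Nc1scc(-c2ccc([N+](=O)[O-])cc2)c1C(=O)c1ccccc1`, gives 47%
compound 3, `COc1cccc(-c2csc(N)c2C(=O)c2ccccc2)c1`, gives 34%

Compound 1 and compound 2 share the same atoms joined differently; the difference between the two cores is not broken down here, and their two values lie within the scatter of each other. One change has been measured: from compound 1 to compound 3, (methoxy in place of nitro on an aromatic carbon), the step was a number 16 percentage points lower from compound 1 to compound 3 (beyond the scatter).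

Compound 4, `COc1ccc(-c2csc(N)c2C(=O)c2ccccc2)cc1`, differs from compound 2 by methoxy in place of nitro on an aromatic carbon. This is the same kind of change, though not the same one: in the measured pair the place is meta to a large group, here it is para to a large group. Because the measured step was a number 16 percentage points lower from compound 1 to compound 3 (beyond the scatter), compound 4 is expected to fall by a number 14 percentage points lower from compound 2 to compound 4 (beyond the scatter). The estimate for compound 4 is 33%, between 18% and 48%.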

Compound 4, a percentage reported as activity, at one concentration (the size of the read-out at that concentration, not a potency): 52%
For compound 4 the middle estimate is 19 percentage points below the measured one; measured number above the stated range.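

In this assay, methoxy in place of nitro on an aromatic carbon, para to a large group, gave a number 5 percentage points higher from compound 2 to compound 4 (within the scatter). Set beside the earlier step, the same change did not carry over unchanged from one core to the other: the same change on two cores in this assay, a number 16 percentage points lower (beyond the scatter) from compound 1 to compound 3 and a number 5 percentage points higher (within the scatter) from compound 2 to compound 4, 21 percentage points apart, beyond the scatter of two such steps. This shows that the step measured on one core cannot be assumed on the other in this series, but two pairs do not show what sets them apart or how the change would behave on any further core.

The compounds shown leave open how an amine or a carboxylic acid would read in place of nitro or methoxy on either core.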